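Sulfanyl side-chain variation on a shared amide core

This account rests on a few compounds, and the source may have more. Where it says the series, first, only, none or still open, it means among the compounds named here.

Measured compounds in an assay on CHO-K1 cells for antagonist activity at transient receptor potential cation channel subfamily V member 1 (Homo sapiens), read by FLIPR; on this read-out higher numbers stand for weaker inhibition and lower numbers for stronger inhibition:
- compound 1 `CCCCCSc1nc(C(F)(F)F)ccc1CNC(=O)C(C)c1ccc(NS(C)(=O)=O)c(F)c1`: 2.5 nM
- compound 2 `CC(C(=O)NCc1ccc(C(F)(F)F)nc1SCCC(=O)N1CCCC1)c1ccc(NS(C)(=O)=O)c(F)c1`: 85 nM
- compound 3 `COc1ccc(CSc2nc(C(F)(F)F)ccc2CNC(=O)C(C)c2ccc(NS(C)(=O)=O)c(F)c2)cc1`: 2.3 nM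

Compound 2 stands at the highest of the three numbers in this assay. Its nearest neighbour is compound 1, with a 34-fold higher number from compound 1 to compound 2 (1.53 log units; beyond the scatter); the gap to compound 3 is larger still, a 37-fold lower number from compound 2 to compound 3 (1.57 log units; beyond the scatter). Compound 1 and compound 3 sit within the scatter of each other, a 1.1-fold lower number from compound 1 to compound 3 (0.04 log units; within the scatter), so the two lipophilic ends on the sulfanyl chain read alike.

Compound 4 `CC(C(=O)NCc1ccc(C(F)(F)F)nc1SCCc1ccccc1)c1ccc(NS(C)(=O)=O)c(F)c1` is not yet measured. Relative to compound 2 it carries phenyl in place of (pyrrolidin-1-yl)carbonyl on a saturated chain carbon, two bonds along the chain from a sulfur. Going by the values given here, two measured steps bear on this. The move from compound 2 to compound 3, which also removes the pyrrolidinyl carbonyl from the chain and puts an aromatic ring in its place, was large and downward. The move from compound 1 to compound 3 shows that exchanging one hydrocarbon end of the chain for a 4-methoxyphenyl end changes nothing beyond the scatter. A large downward step is therefore expected in this assay, a 28-fold lower number from compound 2 to compound 4 (1.45 log units; beyond the scatter), bringing compound 4 back toward compound 1 and compound 3. Compound 4 is estimated at 3 nM, with a range of 1 nM to 10 nM.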

Compound 4, inhibition constant: 1.9 nM
Compound 4: the middle estimate sits 1.6-fold (0.20 log units) above what was measured, within the range that was stated.
By their numbers in this assay, from the lowest: compounds 4, 3 and 1 (each within the scatter of the next); then compound 2.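

In this assay, the exchange at this chain carbon, two bonds along the chain from a sulfur, gives a 45-fold lower number from compound 2 to compound 4 (1.65 log units; beyond the scatter), so the large gap now appears with the chain up to that carbon unchanged, which the earlier step to compound 3 could not show. The phenyl end also falls in with the other two hydrocarbon-type ends, with a 1.2-fold lower number from compound 3 to compound 4 (0.08 log units; within the scatter) and a 1.3-fold lower number from compound 1 to compound 4 (0.12 log units; within the scatter). Among the four compounds only compound 2 stands apart, and since compound 1 with propyl at this carbon reads alike with compound 4 with phenyl, an aromatic ring at this place is not required to reach the level of compound 1, compound 3 and compound 4.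

No measurement on hand gives a reason for the gap between compound 2 and the other three compounds. The compounds shown do not separate the part played by the carbonyl from that of the pyrrolidine ring, and it remains open how a dimethylamino end, a carboxylic acid or a longer chain at this carbon would read.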